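The compounds below may be only part of what the source reports. "The series", "measured", "known", "first", "only" and "open" are said of these compounds alone.

Compound 1 `CCOc1cc([C@@H](Nc2ccc3cnccc3c2)C(=O)NS(=O)(=O)c2ccccc2)ccc1OC(C)C`: in an assay on isolated protein for inhibition of Trypsin (Homo sapiens) (on this read-out higher numbers stand for weaker inhibition and lower numbers for stronger inhibition), compound 1 gives > 5000 nM, which is a limit of the assay rather than a number.
Compound 2 `CCOc1cc(C(Nc2ccc3cnccc3c2)C(=O)NS(=O)(=O)c2ccccc2)ccc1OC(C)C`: in this assay compound 2 gives > 5000 nM, again a limit of the assay.

Going by the values given here, compound 1 therefore stands at the limit, and the only other value shown sits there as well. Among the compounds with values here, the single measured step, a step that the two limits leave unreadable from compound 1 to compound 2, cannot be read in size because of the limit of > 5000 nM in this assay, at which 2 of the 2 values shown sit; the two structures differ only in that (the fact that one of compounds 1 and 2 is drawn with a defined configuration and the other without, at the place where they differ). Compound 3 `CCOc1cc([C@@H](Nc2ccc3cnccc3c2)C(=O)NS(=O)(=O)c2cccc(S(N)(=O)=O)c2)ccc1OC(C)C` differs from compound 1 by sulfamoyl in place of hydrogen on an aromatic carbon. No measured step carries a change of this kind, and the one step shown gives no size, so the only footing for an expectation is that compound 1 sits at the limit. Compound 3 is accordingly expected to stay at or near that limit, with a step that the limit leaves unreadable from compound 1 to compound 3 as the estimated step. The estimate for compound 3 in this assay is 10000 nM, with a range from 3000 nM to 50000 nM.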

Compound 3, inhibition constant: > 5000 nM
Compound 3 was reported as a limit; the forecaster's own chance of this, stated with the estimate: 80%; the middle value lies beyond the limit too.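

Compound 3 gives > 5000 nM in this assay, which is a limit of the assay and not a number. Going by these compounds alone, compound 1 sits at the same limit, so no step between compound 1 and compound 3 can be read. The compounds shown leave open whether sulfamoyl in place of hydrogen, or the drawn configuration, changes the read-out in this assay at all.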